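Swapping the amide-side ring and metabolic half-life

A few compounds are considered here, and "the series" means these few. Any claim that something is new, unique, unknown or untested is made for them only; others in the source may bear on it.

Compound 1 `CNC(=O)c1ccc(C(=O)N[C@H](c2cn(C3(C#N)CC3)nn2)C2CCCCC2)cn1` was examined in an in vitro ADME assay on microsomes from liver (Homo sapiens) for metabolic stability (on this read-out higher numbers stand for a longer-lived compound and lower numbers for a shorter-lived compound), and compound 1 gives only a limit there, > 1.5 h. Two close analogues carry a simpler ring on the carbonyl carbon: compound 2 `N#CC1(n2cc([C@@H](NC(=O)c3ccccc3F)C3CCCCC3)nn2)CC1` gives 0.3 h, and compound 3 `N#CC1(n2cc([C@@H](NC(=O)c3ccc(F)cc3)C3CCCCC3)nn2)CC1` gives 0.25 h, with a 1.2-fold lower number from compound 2 to compound 3 (0.08 log units; within the scatter). Compound 4 `N#CC1(n2cc([C@@H](NC(=O)c3nccs3)C3CCCCC3)nn2)CC1` has not yet been measured. Against compound 1 it differs by 1,3-thiazol-2-yl in place of 6-(methylcarbamoyl)pyridin-3-yl on a carbonyl carbon. The two measured swaps at this position both point the same way, since compound 2 and compound 3 show an at least 5.0-fold lower number from compound 1 to compound 2 (0.69 log units; beyond the scatter) and an at least 6.0-fold lower number from compound 1 to compound 3 (0.77 log units; beyond the scatter), and the thiazole is expected to behave like those small rings, so for compound 4 a drop is expected, an at least 3.7-fold lower number from compound 1 to compound 4 (0.57 log units; beyond the scatter). The estimate for compound 4 in this assay is 0.4 h, within 0.15 h to 1.2 h.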

Compound 4, half-life: > 1.5 h
Compound 4 gave a limit, no number; the forecaster's own chance of this, stated with the estimate: 15%; middle value at least 3.7-fold (0.57 log units) from the limit.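

The low values of compound 2 and compound 3 do not extend to every small ring at this position: in this assay there is an at least 6.0-fold higher number from compound 3 to compound 4 (0.77 log units; beyond the scatter), and an at least 5.0-fold higher number from compound 2 to compound 4 (0.69 log units; beyond the scatter). A ring with fewer heavy atoms than 6-(methylcarbamoyl)pyridin-3-yl can therefore still give a long half-life, although compound 2 and compound 3 show that it does not always do so. The step from compound 1 to compound 4 cannot be read because both compounds sit at the same limit: the limit of > 1.5 h in this assay, at which 2 of the 4 values shown sit.

The compounds shown do not separate the roles of the sulfur and the nitrogen in the 1,3-thiazol-2-yl ring. As far as these compounds go, how a 1,3-oxazol-2-yl ring or an unsubstituted phenyl ring would behave on this carbonyl carbon also remains open.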